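A few compounds are considered here, and "the series" means these few. Any claim that something is new, unique, unknown or untested is made for them only; others in the source may bear on it.

In a functional assay on MCF7 cells (Homo sapiens) for antiproliferative activity, with a stated time of 48 h (on this read-out higher numbers stand for weaker inhibition and lower numbers for stronger inhibition), compound 2, `CC(C)(C)c1ccc(CNC(=O)NC(=O)CCl)cc1`, gives 2800 nM, the lowest of the two numbers available. Compound 3, `O=C(CCCl)Nc1ccc(I)cc1`, gives 26000 nM in this assay. Compound 1, `O=C(NCCCCl)Nc1ccc(I)cc1`, reaches only the limit > 100000 nM in this assay, and that is a limit rather than a number; it sits at the limit of > 100000 nM in this assay, at which 1 of the 3 values shown sits.

Compound 4, `CC(C)(C)c1ccc(CNC(=O)CCCl)cc1`, has not yet been measured in this assay. It differs from compound 2 in one place: 2-chloroethyl in place of ((chloromethyl)carbonyl)amino on a carbonyl carbon.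

For the measured compounds named here, the one measured step that resembles this change is an at least 3.8-fold lower number from compound 1 to compound 3 (0.58 log units; beyond the scatter), where a chloroalkyl chain replaced a chloroalkylamino group on a carbonyl carbon and the number fell. That step starts from a limit, so its true size is not known, and the group leaving compound 2 is not the same as the group leaving compound 1. On this thin evidence the direction is uncertain, and a step of no more than modest size either way is expected, a 1.8-fold higher number from compound 2 to compound 4 (0.25 log units; within the scatter). Compound 4 is therefore expected to give about 5000 nM in this assay, within 1200 nM to 25000 nM.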

Compound 4, half-maximal inhibitory concentration: 67000 nM
Compound 4: middle estimate off by 13-fold (1.13 log units), on the low side; the whole stated range lies below it.
By their numbers in this assay, from the lowest: compound 2; then compound 3; then compound 4. At a limit, above all of these: compound 1.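

In this assay, the ((chloromethyl)carbonyl)amino group on this carbonyl carbon matters greatly on the shared core, as putting 2-chloroethyl in its place gives a 24-fold higher number from compound 2 to compound 4 (1.38 log units; beyond the scatter). The same entering group went the other way in an at least 3.8-fold lower number from compound 1 to compound 3 (0.58 log units; beyond the scatter), so 2-chloroethyl on a carbonyl carbon has no single direction across the compounds shown, and the two steps differ both in the group that leaves and in the rest of the molecule. Nothing measured here gives a cause for the new step.

Which part of the leaving group carries the difference remains open, whether its chlorine, its carbonyl or its amide hydrogen. An acetylamino group or a 3-chloropropyl chain at this place on the core of compound 2 would begin to separate these.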